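The compounds below may be only part of what the source reports. "The series", "measured", "known", "first", "only" and "open" are said of these compounds alone.

Compound 1 `COc1cc(OC)c(OC)cc1/C=C/C(=O)c1ccc(O)cc1` is the starting point. In a functional assay on cells (Erythrocyte, Rattus norvegicus) for inhibition, read by hemolysis, with a stated time of 1 h (on this read-out higher numbers stand for weaker inhibition and lower numbers for stronger inhibition), compound 1 gives 2.29 ug/mL. Two other compounds share its core: compound 2 `COc1cc(C(=O)/C=C/c2cc(OC)c(OC)cc2OC)ccc1O`, which in this assay gives 2.16 ug/mL, and compound 3 `COc1cc(OC)c(OC)cc1/C=C/C(=O)c1cccc([N+](=O)[O-])c1`, which gives 2.21 ug/mL. Compound 1 holds the highest of the three numbers, but the gaps to compound 3 and to compound 2 both lie within the usual scatter, so the three sit together. For the measured compounds named here, the one measured step between neighbours, a 1.1-fold lower number from compound 1 to compound 2 (0.03 log units; within the scatter), is likewise within the scatter.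

Compound 4 `COc1cc(OC)c(OC)cc1/C=C/C(=O)c1ccc(Br)cc1` differs from compound 1 in one place: bromo in place of hydroxy on an aromatic carbon. Going by the values given here, no measured step involves a bromo group or the loss of the hydroxy group. Among the compounds with values here, the only step available, the methoxy in place of hydrogen that takes compound 1 to compound 2, did not move the number beyond the scatter, and compound 3 with its nitro group shows a number close to compound 1 as well. On this thin basis the step of a 1.0-fold higher number from compound 1 to compound 4 (0.00 log units; within the scatter) is expected to stay within the scatter, with no clear direction. Compound 4 is therefore estimated at 2.3 ug/mL in this assay, within a range of 1 ug/mL to 5.5 ug/mL.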

Compound 4, half-maximal inhibitory concentration: 2.3 ug/mL
The estimate for compound 4 equals the measured number at the digits printed; the measured number falls inside the stated range.
By their numbers in this assay, from the lowest: compounds 2, 3, 1 and 4 (each within the scatter of the next).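

On the aromatic carbon para to a large group, the change from 4-hydroxyphenyl to 4-bromophenyl gives a 1.0-fold higher number from compound 1 to compound 4 (0.00 log units; within the scatter) in this assay. Here a hydroxy, counted as both a hydrogen-bond donor and a hydrogen-bond acceptor, gives way to a bromo, counted as neither, and the number stays within the scatter; the earlier step from compound 1 to compound 2 had kept the hydroxy in place, so only this step shows that its replacement by bromo leaves the read-out unmoved. There is no measurement at hand that could explain this result.

The compounds shown leave open how an amine, a carboxylic acid or a longer chain such as butoxy would read at this same place, since compounds 1, 2, 3 and 4 all lie within the scatter of their neighbours and none of them marks a change that moves the number beyond it. They also leave open what happens to the number when the methoxy groups shared by compound 1 and compound 4 are replaced by hydrogen or by ethoxy.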